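Cytotoxicity notes: a chloro step repeated on a second core

This account rests on a few compounds, and the source may have more. Where it says the series, first, only, none or still open, it means among the compounds named here.

Compound 1 `CC1CCN(C2CCN(S(=O)(=O)c3ccc(-c4ccccc4)cc3)CC2)CC1` is the parent of the set. In an ADME assay on HCT-116 cells (Homo sapiens) for cytotoxicity, read by CellTiter-Glo, with a stated time of 72 h (a higher number here means a weaker inhibitor, a lower number a stronger inhibitor), compound 1 gives > 5000 nM, which is a limit of the assay and not a number. Compound 2 `CC1CCN(C2CCN(S(=O)(=O)c3ccc(-c4ccc(Cl)cc4)cc3)CC2)CC1` carries the change (chloro in place of hydrogen on an aromatic carbon). In this assay compound 2 gives > 5000 nM, again a limit. The step that the two limits leave unreadable from compound 1 to compound 2 is therefore not readable in size or direction.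

Compound 3 `CC1CCN(C2CCN(S(=O)(=O)c3ccccc3-c3ccccc3)CC2)CC1` is built from the same atoms as compound 1, joined differently; the difference between the two cores is not broken down here. In this assay compound 3 gives > 5000 nM, also a limit.

Compound 4 `CC1CCN(C2CCN(S(=O)(=O)c3ccccc3-c3ccc(Cl)cc3)CC2)CC1` has not yet been measured. It differs from compound 3 by chloro in place of hydrogen on an aromatic carbon, the same change as that from compound 1 to compound 2, and the place is described in the same words in both cases. What is known of this change is summarised by the limit of > 5000 nM in this assay, at which 3 of the 3 values shown sit, so no direction can be taken from the measured pair.

The step that the limit leaves unreadable from compound 3 to compound 4 is expected to be small. That expectation rests on (the limit of > 5000 nM in this assay, at which 3 of the 3 values shown sit), which leaves the earlier step without a readable size. Compound 4 is accordingly expected to sit near 10000 nM, between 4000 nM and 30000 nM, most likely reported again only as a limit.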

Compound 4, half-maximal inhibitory concentration: > 5000 nM
Compound 4 was reported as a limit; the forecaster's own chance of this, stated with the estimate: 85%; the middle value does not contradict the limit.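

No new step can be read: compound 3 and compound 4 are both reported only as limits in this assay, so the change from phenyl to 4-chlorophenyl has no readable size or direction on this core. The compounds shown leave open whether chloro in place of hydrogen changes the read-out on either core, and where any of them would fall as a number, given what is on record: the limit of > 5000 nM in this assay, at which 4 of the 4 values shown sit.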